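This account rests on a few compounds, and the source may have more. Where it says the series, first, only, none or still open, it means among the compounds named here.

Of the compounds shown here, two of a shared core have been measured in an ADME assay on microsomes from liver (Homo sapiens) for metabolic stability, read by mass spectrometry, using NADPH, with a stated time of 10 min; on this read-out lower numbers stand for a less stable compound and higher numbers for a more stable compound. Compound 1 `CCCCc1[nH]c(=O)c(-c2nc(Cc3ccccc3)no2)c(O)c1-c1c(OC)cccc1OC` gives 69%. Compound 2 `CCOCc1[nH]c(=O)c(-c2nnc(Cc3ccc(Cl)cc3)o2)c(O)c1-c1c(OC)cccc1OC` gives 94% in this assay, the highest of the two numbers; the nearest, compound 1, lies lower by an amount beyond the usual scatter. The unmeasured compound 3 `COc1cccc(OC)c1-c1c(C2CCCC2)[nH]c(=O)c(-c2nnc(Cc3ccc(Cl)cc3)o2)c1O` differs from compound 2 in one place: cyclopentyl in place of ethoxymethyl on an aromatic carbon. Among the measured compounds shown here, no pair of measured compounds that differ in a single place is available, so no measured step can guide the size of this change. Compound 1, which carries other groups in this place and elsewhere, gives 69%, while compound 2 gives 94%, so room for movement in both directions is limited chiefly upward. Compound 3 is expected to give a somewhat lower number, a step of a number 14 percentage points lower from compound 2 to compound 3 (beyond the scatter), so that compound 3 is estimated at 80% with a range from 60% to 95%.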

Compound 3, percent of the compound remaining: 80%
For compound 3 middle estimate and measured number coincide at the digits printed; low and high end bracket the measured number.
By their numbers in this assay, from the lowest: compound 1; then compound 3; then compound 2.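

In this assay, among the compounds shown here, replacing ethoxymethyl with cyclopentyl on the aromatic carbon next to the ring nitrogen gives a number 14 percentage points lower from compound 2 to compound 3 (beyond the scatter), the first measured step at this position. With the rest of the structure held fixed, this shows that the group in this place can move the percentage of compound remaining by more than the usual scatter. Nothing at hand gives a cause for this step.

The compounds shown do not separate the presence of a ring from the loss of the oxygen of the chain, a question that a propyl chain or a tetrahydrofuranyl ring in this place could address. As far as these compounds go, how an amine or a carboxylic acid on this carbon would read in this assay also remains open.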